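Swapping Trifluoromethyl for Methoxy on Two Related Cores

A few compounds are considered here, and "the series" means these few. Any claim that something is new, unique, unknown or untested is made for them only; others in the source may bear on it.

Three compounds have been measured in a functional assay on MCF7 cells (Homo sapiens) for inhibition, read by sulforhodamine B assay, with a stated time of 48 h; a higher number here means a weaker inhibitor of growth, a lower number a stronger inhibitor of growth:

Compound 1, `O=C1C=COC(/C=C/c2ccc(C(F)(F)F)cc2)C1`, gives 41.2 uM.
Compound 2, `COc1ccc(/C=C/C2CC(=O)C=CO2)cc1`, gives 156 uM.
Compound 3, `O=C1C=CCC(/C=C/c2ccc(C(F)(F)F)cc2)O1`, gives 51 uM.

Compound 1 and compound 2 share one core and differ in a single group: methoxy in place of trifluoromethyl on an aromatic carbon. This change produced a 3.8-fold higher number from compound 1 to compound 2 (0.58 log units; beyond the scatter), so the methoxy compound is the weaker growth inhibitor of the pair.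

Compound 3 carries the same trifluoromethyl group as compound 1 but sits on a different core; the difference between the two cores is not broken down here. In this assay compound 3 and compound 1 give numbers that lie within the usual scatter of each other, so no order between them can be claimed.

Compound 4, `COc1ccc(/C=C/C2CC=CC(=O)O2)cc1`, has not yet been measured. It differs from compound 3 by the same change that turns compound 1 into compound 2: methoxy in place of trifluoromethyl on an aromatic carbon. The group that leaves, the group that enters and the place are the same in both cases. For the measured compounds named here, with only one measured example of this change, the most reasonable expectation is a step of about the same size on the new core. For compound 4 the expected step is a 3.5-fold higher number from compound 3 to compound 4 (0.55 log units; beyond the scatter), which rests on the measured step of a 3.8-fold higher number from compound 1 to compound 2 (0.58 log units; beyond the scatter) applied to the value of compound 3, 51 uM. Compound 4 is therefore estimated to give 180 uM in this assay, with a plausible range from 80 uM to 400 uM.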

Compound 4, concentration for growth inhibition (reported as GI): 25.5 uM
Beside the measured number, compound 4's estimate is 7.1-fold (0.85 log units) above it; measured number outside the range, below it.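

On the core of compound 3, putting methoxy in place of trifluoromethyl gives a 2.0-fold lower number from compound 3 to compound 4 (0.30 log units; within the scatter), so in this assay no order between these two compounds can be claimed, whereas on the core of compound 1 the methoxy compound was the weaker growth inhibitor. The change therefore did not carry over with the same size from one core to the other: the same change on two cores in this assay, a 3.8-fold higher number (0.58 log units; beyond the scatter) from compound 1 to compound 2 and a 2.0-fold lower number (0.30 log units; within the scatter) from compound 3 to compound 4, 7.6-fold (0.88 log units) apart, beyond the scatter of two such steps. This shows that, among these compounds, a step measured on one core was a poor guide to the same step on the other, but with only one pair per core it does not show why the two cores differ or whether the gap would hold for any other change.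

The compounds shown leave open how each core would respond to other groups on the aromatic carbon, such as a chlorine atom, a nitrile or an amine, and whether those steps would also differ between the cores. They also leave open how a plain hydrogen at that place would compare on each core, which would give both the trifluoromethyl and methoxy compounds a common point of reference.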